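Swapping oxygen for sulfur on the semicarbazone tail

The source may hold more compounds than are shown below. What is called first, only, known or untested is meant among the compounds shown, and "the series" means these compounds.

Three compounds share one core. Compound 1 `C/C(=N\NC(N)=O)c1ccc2c(c1)nc(-c1ccc(C(F)(F)F)cc1)n2C1CCCCC1` was tested in an ADME assay on Vero cells (Chlorocebus sabaeus) for cytotoxicity, read by MTT assay, with a stated time of 96 h (on this read-out higher numbers stand for lower toxicity in this test and lower numbers for higher toxicity in this test), and compound 1 returned only a limit there, > 100000 nM, which is not a number. In this assay compound 2 `C/C(=N\NC(N)=O)c1ccc2c(c1)nc(-c1ccoc1)n2C1CCCCC1` gives "not determined" (no result reported), so no result of any kind exists for it. Across these two compounds no single number stands for compound 2 at all, and the one value shown is a limit (the limit of > 100000 nM in this assay, at which 1 of the 2 values shown sits). Within the data shown here, no step between measured compounds can therefore be drawn.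

Compound 3 `C/C(=N\NC(N)=S)c1ccc2c(c1)nc(-c1ccoc1)n2C1CCCCC1` differs from compound 2 in one place (a group of 3 heavy atoms (1 carbon, 1 nitrogen, 1 sulfur; no ring) in place of a group of 3 heavy atoms (1 carbon, 1 nitrogen, 1 oxygen; no ring), on an amine nitrogen). Among the measured compounds shown here, with no measured step to lean on, the expected size of any step in this assay is open; a change within the usual scatter or a modest shift in either direction would both be plausible, and a limit again is quite possible.

On that basis, compound 3 is estimated to give 60000 nM in this assay, with an expected range from 10000 nM to 200000 nM.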

Compound 3, half-maximal cytotoxic concentration: 25000 nM
Compound 3: middle estimate off by 2.4-fold (0.38 log units), on the high side; the measured number falls inside the stated range.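

Compound 2 carries no number in this assay, so no step can be read to compound 3, which gives 25000 nM. Compound 1 offers only a limit, not a number: the limit of > 100000 nM in this assay, at which 1 of the 3 values shown sits. What the compounds shown leave open is whether replacing the carbamoyl group with its sulfur counterpart changes the cytotoxicity reading at all.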